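Purine series: thioether to ether, cytotoxicity expectations

This account rests on a few compounds, and the source may have more. Where it says the series, first, only, none or still open, it means among the compounds named here.

Two compounds of the shared core have been run in an ADME assay on MOLT-3 cells (Homo sapiens) for cytotoxicity, with a stated time of 7 days; on this read-out lower numbers stand for higher toxicity in this test and higher numbers for lower toxicity in this test. Compound 1 `CC(C)CSc1nc(N)nc2c1ncn2/C=C1/CC1(CO)CO` gives "not determined" (no result reported) in this assay. For compound 2 `CCCCCCCCSc1nc(N)nc2c1ncn2/C=C1/CC1(CO)CO` this assay returns only a limit, > 20000 nM, and not a number. Compound 2 thus stands at the ceiling of what has been recorded so far: the limit of > 20000 nM in this assay, at which 1 of the 2 values shown sits, while the other entry carries no number at all. Compound 3 `CCCCCCOc1nc(N)nc2c1ncn2/C=C1/CC1(CO)CO` has not been measured in this assay; it differs from compound 2 in one place, (hexyloxy in place of octylsulfanyl on an aromatic carbon). Among the measured compounds shown here, no measured step between two compounds exists for comparison, so there is nothing to scale this change against. The expectation is no change beyond the usual scatter, as compound 2 already sits at the limit > 20000 nM in this assay. The step from compound 2 to compound 3 is expected to be a step that the limit leaves unreadable from compound 2 to compound 3. Compound 3 is estimated at 30000 nM, between 15000 nM and 60000 nM, most likely again returned as a limit.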

Compound 3, half-maximal cytotoxic concentration: > 20000 nM
Compound 3 was reported as a limit (the forecaster's own chance of this, stated with the estimate: 80%); the middle value does not contradict the limit.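

Compound 2 and compound 3 give no readable step in this assay, since both results are limits and not numbers: the limit of > 20000 nM in this assay, at which 2 of the 3 values shown sit.

The compounds shown leave open whether any group at this aromatic carbon gives a measurable half-maximal cytotoxic concentration in this assay.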